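Adding a methoxy group to compound 3's aryl imine

The source may hold more compounds than are shown below. What is called first, only, known or untested is meant among the compounds shown, and "the series" means these compounds.

Compound 3 `Cc1nc2c(cnn2S(=O)(=O)c2ccc(Cl)cc2)c(=O)n1/N=C/c1ccccc1` gives 22400 nM in a functional assay on MCF7 cells (Homo sapiens) for cytotoxicity, read by colorimetric assay and sulforhodamine B assay, with a stated time of 48 h (on this read-out lower numbers stand for stronger inhibition and higher numbers for weaker inhibition), the second highest of three numbers; compound 2 `COc1cc(/C=N/n2c(C)nc3c(cnn3-c3ccc(Cl)cc3)c2=O)ccc1O` gives 19800 nM and compound 1 `COc1ccc(/C=N/n2c(C)nc3c(cnn3-c3ccc(Cl)cc3)c2=O)cc1` gives 38600 nM, both within the scatter of compound 3. Compound 4 `COc1ccc(/C=N/n2c(C)nc3c(cnn3S(=O)(=O)c3ccc(Cl)cc3)c2=O)cc1` differs from compound 3 by methoxy in place of hydrogen on an aromatic carbon. Among the compounds with values here, no measured pair shows exactly hydrogen against methoxy on that ring. The closest step, a 1.9-fold lower number from compound 1 to compound 2 (0.29 log units; within the scatter), changes a group on the same ring and stays within the scatter, and compounds 1 and 3 carry two differences at once, so they cannot isolate this change. No step beyond the scatter is therefore expected for a 1.1-fold higher number from compound 3 to compound 4 (0.03 log units; within the scatter). Compound 4 is expected to give 24000 nM, estimated between 10000 nM and 55000 nM.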

Compound 4, half-maximal inhibitory concentration: 41900 nM
Compound 4: middle estimate off by 1.7-fold (0.24 log units), on the low side, within the range that was stated.
By their numbers in this assay, from the lowest: compounds 2, 3, 1 and 4 (each within the scatter of the next, the first and the last beyond it).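

In this series, the change from phenyl to 4-methoxyphenyl can now be read directly in this assay (a 1.9-fold higher number from compound 3 to compound 4 (0.27 log units; within the scatter)), and the step stays within the usual scatter. The link on the aromatic nitrogen can also be read alone, with (4-chlorophenyl)sulfonyl in place of 4-chlorophenyl (a 1.1-fold higher number from compound 1 to compound 4 (0.04 log units; within the scatter)), and that step also stays within the scatter. No measurement offers an explanation for either step. On these data alone, it remains open whether a different group at this ring position, such as an amine or a carboxylic acid, would produce a step beyond the scatter.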